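Fluorinated Anilide Series: Antiproliferative Working Notes

The source may report more compounds than this note shows. Statements on the series, on what has been measured and on what is new or still open speak of the compounds shown alone.

All numbers below come from a functional assay on LNCaP cells (Homo sapiens) for antiproliferative activity, read by propidium iodide staining, with a stated time of 96 h; a lower number here means a stronger inhibitor, a higher number a weaker inhibitor.

compound 1, `CC(O)(COc1ccc(S(F)(F)(F)(F)F)cc1)C(=O)Nc1ccc(S(F)(F)(F)(F)F)cc1`, gives 9800 nM
compound 2, `CC(O)(COc1ccc(S(F)(F)(F)(F)F)cc1)C(=O)Nc1cccc(S(F)(F)(F)(F)F)c1`, gives 8000 nM
compound 3, `CC(O)(COc1ccc(C(F)(F)F)cc1)C(=O)Nc1cccc(S(F)(F)(F)(F)F)c1`, gives 9600 nM

The three measured compounds sit close together in this assay, and none of the gaps between them goes beyond the usual scatter, so no order of potency can be read from them. Compound 1 and compound 2 carry the same atoms joined differently; the difference between the two cores is not broken down here, and their two values show nothing beyond the scatter.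

Within compound 2's core, one change has been measured: a group of 4 heavy atoms (1 carbon, 3 fluorine; no ring) in place of a group of 6 heavy atoms (5 fluorine, 1 sulfur; no ring), on an aromatic carbon. It gave a 1.2-fold higher number from compound 2 to compound 3 (0.08 log units; within the scatter), a step that counts as no change at all.

Compound 4, `CC(O)(COc1ccc(S(F)(F)(F)(F)F)cc1)C(=O)Nc1ccc(C(F)(F)F)cc1`, is not yet measured. Going by the values given here, it differs from compound 1 by a group of 4 heavy atoms (1 carbon, 3 fluorine; no ring) in place of a group of 6 heavy atoms (5 fluorine, 1 sulfur; no ring), on an aromatic carbon, the same kind of change as the one from compound 2 to compound 3, and the description of the place is the same word for word in both cases. Among the compounds with values here, the only evidence on this change is the step from compound 2 to compound 3, so the expectation for compound 4 rests on that single step and on the value of compound 1, 9800 nM, as the starting point.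

For compound 4 the expected step is a 1.2-fold higher number from compound 1 to compound 4 (0.07 log units; within the scatter), which is meant to mirror the earlier step within the scatter. Compound 4 is therefore estimated at 11500 nM, with a plausible range from 5000 nM to 26000 nM; this is an expectation drawn from one prior example only.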

Compound 4, half-maximal inhibitory concentration: 11700 nM
The estimate for compound 4 lay 1.0-fold (0.01 log units) below the measured number; the range from low to high includes it.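

Replacing the group of five fluorine atoms and one sulfur with trifluoromethyl, on an aromatic carbon of the core of compound 1, gave a 1.2-fold higher number from compound 1 to compound 4 (0.08 log units; within the scatter) in this assay. Set beside the earlier step, the same change reads alike on the two cores: the same change on two cores in this assay, a 1.2-fold higher number (0.08 log units; within the scatter) from compound 2 to compound 3 and a 1.2-fold higher number (0.08 log units; within the scatter) from compound 1 to compound 4, 1.0-fold (0.00 log units) apart, within the scatter of two such steps

This shows that, across these two cores, the swap gives no step beyond the scatter, so in this series the two groups cannot be told apart in this assay; it does not show that the change carries a real effect of any fixed size from one core to another, since two steps within the scatter agree only in showing nothing measurable, and the change falls on a different aromatic ring in each of them.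

The compounds shown leave open whether any other group in this place, such as a nitrile, an amine or a carboxylic acid, would give a step beyond the scatter. They also leave open what a change to the hydroxyl or the amide hydrogen, both common to all four compounds, would do to the number.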